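Removing the Chloro Group from a Bombesin Receptor Agonist

A few compounds are considered here, and "the series" means these few. Any claim that something is new, unique, unknown or untested is made for them only; others in the source may bear on it.

Measured in an in vitro functional assay on cells for agonist activity at Bombesin receptor subtype-3 (Mus musculus), read by luminescence and calcium flux; on this read-out higher numbers stand for an effect only at larger amounts of compound and lower numbers for an effect already at smaller amounts:

Compound 1, `O=C(O)c1ccccc1-c1ccc(CCc2ncc(Cc3ccc(Cl)cc3)[nH]2)cc1`, gives 102 nM.
Compound 2, `CCCCc1cnc(C(CC)Cc2ccc(-c3ccccc3C(=O)O)cc2)[nH]1`, gives 340 nM.
Compound 3, `CCCCc1cnc(C(CCCO)Cc2ccc(-c3ccccc3C(=O)O)cc2)[nH]1`, gives 238 nM.

Of these three, compound 1 shows the lowest number in this assay. Compound 3 stands above it by a gap beyond the usual scatter, and compound 2 stands further above still. Going by the values given here, the one step between measured compounds that differ in a single place is a 1.4-fold lower number from compound 2 to compound 3 (0.15 log units; within the scatter), and it concerns hydroxymethyl in place of hydrogen on a saturated chain carbon, three bonds along the chain from an aromatic carbon, a part of the molecule unrelated to the change considered here.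

Compound 4, `O=C(O)c1ccccc1-c1ccc(CCc2ncc(Cc3ccccc3)[nH]2)cc1`, has not yet been measured in this assay. It differs from compound 1 in one place: hydrogen in place of chloro on an aromatic carbon. Among the compounds with values here, no measured step removes or adds a chloro group, so there is no direct precedent among the three compounds, and the step from compound 2 to compound 3 does not bear on it. Compound 4 is expected to give a moderately higher number than its parent, a step estimated as a 2.5-fold higher number from compound 1 to compound 4 (0.41 log units; beyond the scatter). The estimate for compound 4 is 260 nM, with a range from 90 nM to 800 nM.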

Compound 4, half-maximal effective concentration: 11 nM
Compound 4: the middle estimate sits 24-fold (1.37 log units) above what was measured; measured number outside the range, below it.
By their numbers in this assay, from the lowest: compound 4; then compound 1; then compounds 3 and 2 (each within the scatter of the next).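

In this assay, going from 4-chlorobenzyl to benzyl gives a 9.3-fold lower number from compound 1 to compound 4 (0.97 log units; beyond the scatter) and so shows that the chloro group is not needed for a low number on this scaffold, since the unsubstituted ring does clearly better. Going by these compounds alone, this is also the first sign that this position matters: the only earlier single-place step, on a saturated chain in another part of the molecule, stayed within the scatter, while the exchange of one chlorine atom for a hydrogen atom here goes well beyond it. No measurement at hand bears on the reason for this step.

With only chloro and hydrogen on this aromatic carbon, the compounds shown leave open whether a fluoro, a methyl or a methoxy group in the same place would give a number nearer that of compound 1 or that of compound 4. They also leave open whether removing a chloro group would have a similar effect on another core, as this single pair of compounds sets no general pattern.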